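Propargyl for Methyl on Selenium: Compound 3 to Compound 4

This account rests on a few compounds, and the source may have more. Where it says the series, first, only, none or still open, it means among the compounds named here.

Going by the values given here, compound 3 `C[Se]c1c(SCC#CCO)cnc2ccccc12` stands second highest of the three numbers so far in a functional assay on P388 cells (Mus musculus) for cytotoxicity, read by MTT assay, with a stated time of 72 h (on this read-out lower numbers stand for stronger inhibition and higher numbers for weaker inhibition), giving 19.8 ug/mL. Its nearest neighbour is compound 2 `OCC#CCSc1cnc2ccccc2c1SCC#CCBr`, which gives 43.2 ug/mL; the step between them is a 2.2-fold lower number from compound 2 to compound 3 (0.34 log units; beyond the scatter). The furthest is compound 1 `OCC#CCSc1cnc2ccccc2c1Cl`, which gives 2.4 ug/mL; the corresponding step is an 8.3-fold higher number from compound 1 to compound 3 (0.92 log units; beyond the scatter).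

Compound 4 `C#CC[Se]c1c(SCC#CCO)cnc2ccccc12` differs from compound 3 by ethynyl in place of hydrogen on a saturated chain carbon bound to a selenium atom.

Among the compounds with values here, no measured step touches the chain on the selenium; all three vary the group on the same aromatic carbon. They do show what happens when that group grows: an 18-fold higher number from compound 1 to compound 2 (1.26 log units; beyond the scatter) for the six-heavy-atom chain against chlorine, an 8.3-fold higher number from compound 1 to compound 3 (0.92 log units; beyond the scatter) for the two-heavy-atom group against chlorine, and a 2.2-fold lower number from compound 2 to compound 3 (0.34 log units; beyond the scatter) when the larger group gives way to the smaller. Within these three compounds, a larger group at that carbon goes with a higher number. Methyl to propargyl adds two carbons, a smaller growth than either measured one, so only a small rise, near the edge of the scatter, is expected, a 1.5-fold higher number from compound 3 to compound 4 (0.18 log units; within the scatter). Compound 4 is estimated at 30 ug/mL, within 12 ug/mL to 75 ug/mL.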

Compound 4, concentration for 50% inhibition: 2.5 ug/mL
Compound 4: the middle estimate sits 12-fold (1.08 log units) above what was measured; the measured number lies below the stated range.
By their numbers in this assay, from the lowest: compounds 1 and 4 (each within the scatter of the next); then compound 3; then compound 2.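

In this assay, the chain on the selenium proves to be a sensitive place in the series: methyl to propargyl alone gives a clear drop (a 7.9-fold lower number from compound 3 to compound 4 (0.90 log units; beyond the scatter)), and compound 4 goes against the earlier link between a larger group on the aromatic carbon and a higher number. The bigger selenium group of compound 4 sits far lower than the chain of compound 2 (a 17-fold lower number from compound 2 to compound 4 (1.24 log units; beyond the scatter)) and cannot be told apart from the chlorine of compound 1 (a 1.0-fold higher number from compound 1 to compound 4 (0.02 log units; within the scatter)), so the size of the group does not by itself set the number, and what is attached at the end of the chain counts as well. Nothing at hand gives a reason for the drop on going from methyl to propargyl.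

Still open, from the compounds shown here alone, is whether the triple bond is what matters, or whether a propyl or allyl chain on the selenium would bring the same drop. Also open, going by these compounds, is whether propargyl acts the same way on a sulfur atom in place of the selenium, and whether a longer chain such as butynyl keeps the low number.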